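Sulfonamide substituent variations on the shared core

The compounds below may be only part of what the source reports. "The series", "measured", "known", "first", "only" and "open" are said of these compounds alone.

Compound 1 `CS(=O)(=O)Nc1ccc(-c2nc3ccccc3o2)cc1` carries a methyl group on the sulfonyl sulfur. In an assay on isolated protein for inhibition of malate dehydrogenase, mitochondrial (Sus scrofa), with stated times of 45 min and 30 min (on this read-out higher numbers stand for weaker inhibition and lower numbers for stronger inhibition), compound 1 reaches only a limit of the assay, > 63000 nM. Compound 2 `O=S(=O)(Nc1ccc(-c2nc3ccccc3o2)cc1)c1ccccc1F` carries a 2-fluorophenyl group in that place; in this assay compound 2 likewise gives only a limit, > 63000 nM. Compound 3 `C=Cc1ccc(S(=O)(=O)Nc2ccc(-c3nc4ccccc4o3)cc2)cc1` carries a 4-vinylphenyl group; in this assay compound 3 again gives only a limit, > 63000 nM. Compound 3 therefore stands where every compound shown stands, at the limit of > 63000 nM in this assay, at which 3 of the 3 values shown sit, and the steps a step that the two limits leave unreadable from compound 1 to compound 2, a step that the two limits leave unreadable from compound 1 to compound 3 and a step that the two limits leave unreadable from compound 2 to compound 3 cannot be sized. Compound 4 `COc1ccc(Cl)cc1S(=O)(=O)Nc1ccc(-c2nc3ccccc3o2)cc1` differs from compound 3 by 5-chloro-2-methoxyphenyl in place of 4-vinylphenyl on a sulfonyl sulfur. Every measured step that bears on exchanging the group on the sulfonyl sulfur is unreadable, so no direction in this assay can be drawn from them, and a further limit is the most plausible outcome. The step from compound 3 to compound 4 is expected to be a step that the limit leaves unreadable from compound 3 to compound 4. Compound 4 is estimated at 100000 nM, with a range of 30000 nM to 400000 nM, most likely reported again only as a limit.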

Compound 4, half-maximal inhibitory concentration: > 63000 nM
Compound 4 was reported as a limit; the forecaster's own chance of this, stated with the estimate: 85%; the middle value is on the limit's open side.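

In this assay compound 4 gives only a limit (> 63000 nM). The steps to compound 4 from compound 1, compound 2 and compound 3 cannot be read. The compounds shown leave open whether any group on the sulfonyl sulfur of the shared core gives a readable value in this assay at all: the limit of > 63000 nM in this assay, at which 4 of the 4 values shown sit.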